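Replacing a Dichlorobenzyl Group with a Fluorobenzyl Group

The source may report more compounds than this note shows. Statements on the series, on what has been measured and on what is new or still open speak of the compounds shown alone.

Three compounds built on a shared core were examined in a functional assay on NCI-H226 cells (Homo sapiens) for inhibition, read by sulforhodamine B assay, with a stated time of 48 h; a higher number here means a weaker inhibitor of growth, a lower number a stronger inhibitor of growth. Compound 2 `Nc1cc(N)c2nc(-c3ccccc3)c(NCc3ccc(Cl)c(Cl)c3)nc2c1` gives 22400 nM in this assay. Compound 3 `CCOC(=O)[C@H](CCC(=O)O)NC(=O)c1ccc(Oc2nc3cc(N)cc(N)c3nc2-c2ccccc2)cc1` gives 2950 nM, a lower number than that of compound 2 by a margin beyond the usual scatter. Compound 1 `CCOC(=O)[C@H](CCC(=O)O)NC(=O)c1ccc(CNc2nc3cc(N)cc(N)c3nc2-c2ccccc2)cc1` reaches only a limit of the assay, < 100000 nM, and no number. Compound 2 therefore stands with the highest of the two numbers available.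

Compound 4 `Nc1cc(N)c2nc(-c3ccccc3)c(NCc3ccc(F)cc3)nc2c1` has not yet been measured and differs from compound 2 in a single place: 4-fluorophenyl in place of 3,4-dichlorophenyl on a saturated chain carbon bound to a nitrogen on an aromatic ring. Among the measured compounds shown here, no measured pair shows this change, so the size of the step is open; a modest step toward a higher number is expected, one that may well remain within the scatter. Compound 4 is accordingly estimated at 35000 nM, with a range from 10000 nM to 100000 nM. That estimate corresponds to an expected step of a 1.6-fold higher number from compound 2 to compound 4 (0.19 log units; within the scatter).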

Compound 4, concentration for 50% growth inhibition: 22400 nM
Compound 4: middle estimate off by 1.6-fold (0.19 log units), on the high side; the measured number falls inside the stated range.
By their numbers in this assay, from the lowest: compound 3; then compounds 2 and 4 (each within the scatter of the next).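

The exchange of 3,4-dichlorobenzyl for 4-fluorobenzyl gives no change at the digits printed from compound 2 to compound 4 (within the scatter) in this assay. Among the compounds shown here, until now no measured pair had touched this position, and this one shows that the two groups cannot be told apart here, even though the entering group carries one fluorine and the leaving group two chlorines. On a saturated chain carbon bound to a nitrogen on an aromatic ring, then, this exchange of halogens on the phenyl ring leaves no readable trace in the growth read-out.

Going by these compounds, whether an amine or a carboxylic acid on that phenyl ring, or a longer chain at the same place, would stand apart from these two groups remains open. Compound 1 still offers a limit and not a number: the limit of < 100000 nM in this assay, at which 1 of the 4 values shown sits.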